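The source may hold more compounds than are shown below. What is called first, only, known or untested is meant among the compounds shown, and "the series" means these compounds.

The study turns on a shared core carrying two 4-nitrophenyl groups, and on the aryl group attached through an amide-type nitrogen. Compound 2 `Cc1cccc(C)c1NC(=O)/C=C/C(=O)N1C/C(=C\c2ccc([N+](=O)[O-])cc2)C(=O)/C(=C/c2ccc([N+](=O)[O-])cc2)C1` carries a 2,6-dimethylphenyl there and in a functional assay on CCRF-CEM cells (Homo sapiens) for cytotoxicity (a higher number here means a weaker inhibitor, a lower number a stronger inhibitor), compound 2 gives 230 nM, the lowest of the three numbers measured. Compound 1 `O=C(/C=C/C(=O)N1C/C(=C\c2ccccc2)C(=O)/C(=C/c2ccccc2)C1)Nc1ccc(Cl)c(Cl)c1` has a different core and a 3,4-dichlorophenyl on the amide nitrogen; in this assay compound 1 gives 350 nM, which lies within the scatter of compound 2. Compound 3 `COc1ccc(NC(=O)/C=C/C(=O)N2C/C(=C\c3ccc([N+](=O)[O-])cc3)C(=O)/C(=C/c3ccc([N+](=O)[O-])cc3)C2)cc1` keeps the core of compound 2 and in this assay compound 3 gives 760 nM; the change a 3.3-fold higher number from compound 2 to compound 3 (0.52 log units; beyond the scatter) was a modest loss.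

Compound 4 `O=C(/C=C/C(=O)N1C/C(=C\c2ccc([N+](=O)[O-])cc2)C(=O)/C(=C/c2ccc([N+](=O)[O-])cc2)C1)Nc1ccc(Cl)cc1` differs from compound 2 by 4-chlorophenyl in place of 2,6-dimethylphenyl on an amide-type nitrogen. Among the compounds with values here, the only step that bears on it is the one from compound 2 to compound 3, since it changes the same aryl group on the same nitrogen; it weakened the inhibitor modestly. Within the data shown here, compound 1 shows a chlorinated phenyl at that position can still give a number close to that of compound 2, but its core differs, so no single step can be drawn from it. Compound 4 is therefore expected to show a small loss, a 1.7-fold higher number from compound 2 to compound 4 (0.24 log units; within the scatter), smaller than that of compound 3. For compound 4 the estimate in this assay is 400 nM, with a range from 180 nM to 900 nM.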

Compound 4, half-maximal inhibitory concentration: 810 nM
Estimate against measurement, compound 4: 2.0-fold (0.31 log units) below; low and high end bracket the measured number.
By their numbers in this assay, from the lowest: compounds 2 and 1 (each within the scatter of the next); then compounds 3 and 4 (each within the scatter of the next).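

In this assay, the step of a 3.5-fold higher number from compound 2 to compound 4 (0.55 log units; beyond the scatter) is a second replacement of the 2,6-dimethylphenyl on the amide-type nitrogen, and its modest size shows that the loss on this core is not confined to the 4-methoxyphenyl of compound 3. The step of a 1.1-fold higher number from compound 3 to compound 4 (0.03 log units; within the scatter), chloro in place of methoxy on an aromatic carbon, lies within the scatter, so these two groups cannot be told apart at this position. Among the three compounds on this core, the 2,6-dimethylphenyl of compound 2 now stands beyond the scatter of both other groups, though nothing presented here accounts for that difference.

The compounds shown leave open whether both methyl groups of the 2,6-dimethylphenyl are needed, and how a plain phenyl or a phenyl carrying an amine or a carboxylic acid would read on the same nitrogen. They also leave open how the 3,4-dichlorophenyl of compound 1 would compare on the core with two 4-nitrophenyl groups, since compound 1 differs from these compounds in more than one place.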